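The source may hold more compounds than are shown below. What is called first, only, known or untested is meant among the compounds shown, and "the series" means these compounds.

Measured so far in a functional assay on MCF7 cells (Homo sapiens) for cytotoxicity, read by MTT assay, with a stated time of 72 h; on this read-out higher numbers stand for weaker inhibition and lower numbers for stronger inhibition:
compound 1, `Cc1cccc(CSc2cc(Cl)c(C)cc2S(=O)(=O)/N=C(\N)n2nccc2-c2ccccc2)c1`: 47000 nM
compound 2, `Cc1cc(S(=O)(=O)/N=C(\N)n2nccc2-c2ccccc2)c(SCc2ccc(C(F)(F)F)cc2)cc1Cl`: 25000 nM
compound 3, `Cc1cc(S(=O)(=O)/N=C(\N)n2nccc2-c2ccccc2)c(SCc2ccccc2C)cc1Cl`: 23000 nM

All three share one core and differ only in the aryl group on a saturated chain carbon bound to a sulfur. Among the measured compounds shown here, compound 3 gives the lowest number of the three; its gap to compound 2 lies within the scatter, and only the step of a 2.0-fold lower number from compound 1 to compound 3 (0.31 log units; beyond the scatter) reaches beyond it, and that modestly. The steps of a 1.9-fold lower number from compound 1 to compound 2 (0.27 log units; within the scatter) and a 1.1-fold lower number from compound 2 to compound 3 (0.04 log units; within the scatter) show that exchanging this aryl group moves the number little.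

Compound 4, `Cc1cc(S(=O)(=O)/N=C(\N)n2nccc2-c2ccccc2)c(SCc2cccc(Cl)c2)cc1Cl`, is the next member, carrying (3-chlorophenyl in place of 2-methylphenyl on a saturated chain carbon bound to a sulfur). Each measured step bears on it, since each varies the same aryl group, and none went past a modest size. For the measured compounds named here, no measured pair places a 3-chlorophenyl on that carbon, so the direction of the change is unknown. The step expected is a 1.3-fold higher number from compound 3 to compound 4 (0.12 log units; within the scatter), staying within the scatter. For compound 4 the estimate in this assay is 30000 nM, with a range from 14000 nM to 65000 nM.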

Compound 4, half-maximal inhibitory concentration: 88000 nM
Beside the measured number, compound 4's estimate is 2.9-fold (0.47 log units) below it; the measured number lies above the stated range.
By their numbers in this assay, from the lowest: compounds 3, 2, 1 and 4 (each within the scatter of the next, the first and the last beyond it).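

In this assay, the aryl group on a saturated chain carbon bound to a sulfur now shows steps beyond the scatter, though still modest ones: 3-chlorophenyl in place of 2-methylphenyl gives a 3.8-fold higher number from compound 3 to compound 4 (0.58 log units; beyond the scatter), and 3-chlorophenyl in place of 4-(trifluoromethyl)phenyl gives a 3.5-fold higher number from compound 2 to compound 4 (0.55 log units; beyond the scatter). Chloro in place of methyl on an aromatic carbon gives a 1.9-fold higher number from compound 1 to compound 4 (0.27 log units; within the scatter), so this exchange does not separate the two compounds on this read-out. No measurement is available that accounts for these steps.

From the compounds shown here alone, it remains open how 2-chlorophenyl or 4-chlorophenyl would compare with 3-chlorophenyl at this position. Also open, going by these compounds, is how the number would respond to an amine or a carboxylic acid on the aryl ring, or to a longer chain in place of the saturated chain carbon.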